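The source may hold more compounds than are shown below. What is called first, only, known or untested is meant among the compounds shown, and "the series" means these compounds.

In a functional assay on OVCAR-8 cells (Homo sapiens) (a lower number here means a stronger inhibitor of growth, a higher number a weaker inhibitor of growth), compound 1 `N#Cc1ccc(/C=C/S(=O)(=O)Cc2ccc(Nc3ncnc4ccccc34)cc2)cc1` reads > 100000 nM, which is a limit of the assay and not a number. Going by the values given here, compound 2 `O=S(=O)(/C=C/c1ccc(Br)cc1)Cc1ccc(Nc2ncnc3ccccc23)cc1` gives 38000 nM, the only actual number available so far. Among the compounds with values here, the one measured step, an at least 2.6-fold lower number from compound 1 to compound 2 (0.42 log units; beyond the scatter), is bromo in place of cyano on an aromatic carbon, and it lies beyond the scatter. One end of that step is the limit of > 100000 nM in this assay, at which 1 of the 2 values shown sits, so it gives only a bound on its size. Compound 3 `O=S(=O)(/C=C/c1ccc(Cl)cc1)Cc1ccc(Nc2ncnc3ccccc23)cc1` alters the same bromo group of compound 2: chloro in place of bromo on an aromatic carbon. This is chloro in place of bromo, para to a large group. Within the data shown here, no measured step covers this exchange, so no shift beyond the scatter is expected in this assay, and no direction is favoured. The expected 1.1-fold higher number from compound 2 to compound 3 (0.02 log units; within the scatter) therefore stays small. Compound 3 is estimated at 40000 nM, with an expected range of 18000 nM to 90000 nM.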

Compound 3, concentration for 50% growth inhibition: > 100000 nM
Compound 3 was reported as a limit (the forecaster's own chance of this, stated with the estimate: 15%); middle value at least 2.5-fold (0.39 log units) from the limit.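

Bromo and chloro are not interchangeable on this aromatic carbon in this assay: an at least 2.6-fold higher number from compound 2 to compound 3 (0.42 log units; beyond the scatter). The reading of compound 3, > 100000 nM, is a limit and not a number, so this step gives only a bound on its size, and the step between compound 1 and compound 3 cannot be read: the limit of > 100000 nM in this assay, at which 2 of the 3 values shown sit. Among the three groups shown in this place, bromo is now the only one that gives an actual number, while chloro and cyano both end at the limit.

As far as these compounds go, it remains open how far apart chloro and cyano really lie in this assay. From the compounds shown here alone, it also remains open whether iodo, fluoro, methyl or methoxy on the same carbon would give a number, and how any of these would stand against bromo.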